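The source may hold more compounds than are shown below. What is called first, only, known or untested is meant among the compounds shown, and "the series" means these compounds.

Measured compounds:
- Compound 1, `O=S(=O)(/C=C\c1ncccc1F)c1cccc(Cl)c1` — 252 nM
- Compound 2, `O=S(=O)(/C=C/c1cccnc1)c1ccccc1F` — 6860 nM
- Compound 3, `O=S(=O)(/C=C/c1cccnc1Cl)c1ccccc1F` — 217 nM

In an assay on U2OS cells for activation of nuclear factor erythroid 2-related factor 2 (Homo sapiens), read by beta-arrestin recruitment, with a stated time of 6 h (a higher number here means that more compound is needed for the effect, a lower number that less compound is needed), compound 3 gives the lowest of the three numbers. Compound 1 lies closest to it, within the scatter, so the two cannot be ordered; compound 2 is furthest, well beyond the scatter. Among the compounds with values here, the one step that can be isolated among the measured compounds is a 32-fold lower number from compound 2 to compound 3 (1.50 log units; beyond the scatter), a large change brought by chloro in place of hydrogen on an aromatic carbon.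

Compound 4, `O=S(=O)(/C=C\c1cccnc1Cl)c1ccccc1F`, is the next compound. Its difference from compound 3 is the two compounds have the same atoms and bonds and differ only in configuration as drawn: 1 of 1 stereo elements differ; a double bond is drawn E in compound 3 and Z in compound 4. Within the data shown here, no measured step bears on this change: compound 1, which also carries a double bond drawn Z, differs from compound 3 in more than one place, so its value cannot be read as a step. Compound 4 is therefore expected to show a 1.4-fold higher number from compound 3 to compound 4 (0.14 log units; within the scatter), with no clear direction. The estimate for compound 4 in this assay is 300 nM, in a range from 70 nM to 1500 nM.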

Compound 4, half-maximal effective concentration: 3390 nM
The estimate for compound 4 lay 11-fold (1.05 log units) below the measured number; measured number outside the range, above it.
By their numbers in this assay, from the lowest: compounds 3 and 1 (each within the scatter of the next); then compound 4; then compound 2.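

The earlier compounds shown here showed only what a ring substituent could do; compound 4 shows that the geometry of the double bond matters just as clearly in this assay. With the chloro group kept in place, the change from E to Z gives a 16-fold higher number from compound 3 to compound 4 (1.19 log units; beyond the scatter), so the number obtained with chloro in place of hydrogen, seen in a 32-fold lower number from compound 2 to compound 3 (1.50 log units; beyond the scatter), holds only for the E form among these compounds. The whole of this step can be assigned to the drawn configuration of the double bond, because nothing else separates the pair: the fact that compounds 3 and 4 differ only in the configuration as drawn

As far as these compounds go, whether the Z form carries the same penalty with other substituents stays open, since compound 1 also has a double bond drawn Z but differs from compound 4 in more than one place. From the compounds shown here alone, how a methoxy group or an amine in place of the chloro would behave in either configuration also remains unknown.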